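A Hydroxyoxetane in Place of a Hydroxypropyl Tail

The source may hold more compounds than are shown below. What is called first, only, known or untested is meant among the compounds shown, and "the series" means these compounds.

Compound 1 `Cc1c(Nc2nc(N)c3c(C#N)c(N4CCC[C@H]4C)n(C)c3n2)cnn1CC(C)(C)O` is the starting point. In an ADME assay on microsomes from liver (Homo sapiens) for pharmacokinetics (a lower number here means slower removal, a higher number faster removal of the compound), compound 1 gives 30 mL/min/kg, the lowest of the three numbers recorded here. Compound 2 `Cc1nn(C)cc1Nc1nc(N)c2c(C#N)c(N3CCC[C@H]3C)n(C)c2n1` gives 70 mL/min/kg in this assay, and compound 3 `C[C@@H]1CCCN1c1c(C#N)c2c(N)nc(Nc3cn(C)nc3Cl)nc2n1C` gives 183 mL/min/kg. Within the data shown here, the only measured step between two compounds that differ in a single place is a 2.6-fold higher number from compound 2 to compound 3 (0.42 log units; beyond the scatter), a chloro in place of a methyl on an aromatic carbon.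

Compound 4 `Cc1c(Nc2nc(N)c3c(C#N)c(N4CCC[C@H]4C)n(C)c3n2)cnn1CC1(O)COC1` differs from compound 1 by 3-hydroxyoxetan-3-yl in place of 1-hydroxy-1-methylethyl on a saturated chain carbon bound to an aromatic nitrogen. No measured step touches this part of the molecule, so the comparison between compound 2 and compound 3 offers no direct guidance, and the data give no reason to expect a change beyond the scatter.

Compound 4 is therefore estimated at 30 mL/min/kg, with a range from 14 mL/min/kg to 65 mL/min/kg. The expected step is no change at the digits printed from compound 1 to compound 4 (within the scatter), which is read as a step within the scatter because compound 1 gives 30 mL/min/kg and nothing measured here argues against it.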

Compound 4, clearance: 35 mL/min/kg
For compound 4 the middle estimate is 1.2-fold (0.07 log units) below the measured one; measured number inside the range.
By their numbers in this assay, from the lowest: compounds 1, 4 and 2 (each within the scatter of the next, the first and the last beyond it); then compound 3.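

In this assay, 3-hydroxyoxetan-3-yl in place of 1-hydroxy-1-methylethyl gives a 1.2-fold higher number from compound 1 to compound 4 (0.07 log units; within the scatter), so the two compounds cannot be told apart in this measurement. Among these compounds, this is the first measured step at this place, on a saturated chain carbon bound to an aromatic nitrogen, and it shows that a four-membered ring with an extra oxygen can enter here without a step beyond the scatter; the earlier step, a chloro in place of a methyl on an aromatic carbon, concerned a different part of the molecule. Nothing available explains why the two numbers lie so close.

The compounds shown leave open how a carboxylic acid or an amine would read at this same place in this assay. A longer chain carrying the hydroxyl also remains an open case.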